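The source may report more compounds than this note shows. Statements on the series, on what has been measured and on what is new or still open speak of the compounds shown alone.

Measured so far:
Compound 1 `COc1ccccc1Cc1cc2c(N)nc(-c3ccc(C(F)F)o3)nc2s1` gives 516 nM in a functional assay on CHO-K1 cells for antagonist activity at adenosine receptor A1 (Homo sapiens), read by a beta-galactosidase reporter and cAMP accumulation, with stated times of 15 min and 6 h; a higher number here means a weaker inhibitor, a lower number a stronger inhibitor.
Compound 2 `Nc1nc(C2CCCO2)nc2sc(Cc3ccccc3)cc12` gives 2950 nM in this assay.

Of these two numbers, compound 2 carries the higher one, so it is the weaker inhibitor of the pair; the gap between compound 2 and compound 1 is described as lying beyond the usual scatter. Compound 3 `N#Cc1cncc(-c2nc(N)c3cc(Cc4ccccc4)sc3n2)c1` has not yet been measured. It differs from compound 2 in one place: 5-cyanopyridin-3-yl in place of oxolan-2-yl on an aromatic carbon. Within the data shown here, no step between measured compounds covers this particular exchange, so the expectation rests only on the two values given. Among the measured compounds shown here, compound 1, which carries an aromatic five-membered group at a comparable point of its core, sits well below compound 2 in this assay, and that is the only guide. The step from compound 2 to compound 3 is therefore expected to be a 3.3-fold lower number from compound 2 to compound 3 (0.52 log units; beyond the scatter), a decrease beyond the scatter but of uncertain size. Compound 3 is estimated to give 900 nM, within a range of 250 nM to 3200 nM.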

Compound 3, inhibition constant: 1160 nM
Estimate against measurement, compound 3: 1.3-fold (0.11 log units) below, within the range that was stated.
By their numbers in this assay, from the lowest: compound 1; then compound 3; then compound 2.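

Exchanging oxolan-2-yl for 5-cyanopyridin-3-yl on the aromatic carbon between two ring nitrogen atoms gives a 2.5-fold lower number from compound 2 to compound 3 (0.41 log units; beyond the scatter) in this assay, the only direct reading of this position among the compounds shown. The step is modest, but it shows that the number in this assay responds to the group at this position when the rest of the structure stays the same. This single exchange alters the ring size, the aromatic character and the presence of a nitrile together, and no measurement here accounts for the step or assigns it to any one of these features.

As far as these compounds go, it remains open how pyridin-3-yl without the nitrile, or a plain phenyl group, would read at this position. Also open, from the compounds shown here alone, is whether the same exchange would give a similar step alongside the methoxy group that compound 1 carries.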